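Swapping Methoxy for Trifluoromethyl in a Stability Comparison

The source may hold more compounds than are shown below. What is called first, only, known or untested is meant among the compounds shown, and "the series" means these compounds.

Of the compounds shown here, two have numbers so far in an ADME assay on microsomes from liver (Rattus norvegicus) for metabolic stability, read by LC-MS, with a stated time of 30 min, tested at 0.1 uM; on this read-out lower numbers stand for a less stable compound and higher numbers for a more stable compound. Compound 1 (`FC(F)(F)Oc1ccc(-c2nc3cnc(Nc4ccccn4)cc3[nH]2)cc1`) gives 61%, and compound 2 (`COc1ccc(Nc2cc3[nH]c(-c4cccc(C(F)(F)F)c4)nc3cn2)nc1`) gives 32%. Compound 2 thus holds the lower of the two numbers, and its gap to compound 1 lies beyond the usual scatter. Within the data shown here, no measured pair differs in one place only, so no single change has yet been followed on this read-out.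

Compound 3 (`FC(F)(F)c1ccc(Nc2cc3[nH]c(-c4cccc(C(F)(F)F)c4)nc3cn2)nc1`) departs from compound 2 at one point: trifluoromethyl in place of methoxy on an aromatic carbon, two atoms from the ring nitrogen and para to a large group (trifluoromethyl in place of methoxy on an aromatic carbon). The expectation therefore rests on thin ground, namely that compound 2 at 32% has room to rise, as compound 1 at 61% shows. In this assay a rise beyond the scatter is expected, with an estimated a number 18 percentage points higher from compound 2 to compound 3 (beyond the scatter), although a smaller move remains possible. Compound 3 is estimated at 50%, with an expected range of 30% to 72%.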

Compound 3, percent of the compound remaining: 89%
Beside the measured number, compound 3's estimate is 39 percentage points below it; measured number above the stated range.
By their numbers in this assay, from the lowest: compound 2; then compound 1; then compound 3.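

In this assay, the replacement of methoxy by trifluoromethyl gives a number 57 percentage points higher from compound 2 to compound 3 (beyond the scatter), a large step and the first one on this read-out that can be tied to a single place. With everything else in compound 2 held fixed, the change from 5-methoxypyridin-2-yl to 5-(trifluoromethyl)pyridin-2-yl is enough to carry this rise, so the aromatic carbon two atoms from the ring nitrogen is a position at which this read-out responds strongly, something the earlier pair could not show, as compound 1 differs from compound 2 in more than one place. Nothing measured for these compounds bears on why the replacement has an effect of this size.

The compounds shown leave open whether the rise comes from the arrival of trifluoromethyl or from the departure of methoxy, as only these two groups are seen at this position, and a hydrogen, a chlorine atom or a nitrile at the same carbon would help to separate the two readings. They also leave open whether the same replacement would give a step of similar size on a compound with a different group on the other side of the shared core.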